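Aminothienopyridine esters: aryl swap at the pyridine carbon

The source may hold more compounds than are shown below. What is called first, only, known or untested is meant among the compounds shown, and "the series" means these compounds.

Measured compounds:
compound 1, `COC(=O)c1sc2cc(-c3cnn(C)c3)cnc2c1N`: > 150000 nM
compound 2, `COC(=O)c1sc2cc(-c3ccc(F)nc3)cnc2c1N`: "not determined" (no result reported)

Working notes. Both measured compounds share one core and differ only in the aromatic group carried on it. In a functional assay on NCI-H460 cells (Homo sapiens) for inhibition, read by sulforhodamine B assay, with a stated time of 48 h (on this read-out lower numbers stand for stronger inhibition of growth and higher numbers for weaker inhibition of growth), compound 1 gives > 150000 nM, which is a limit of the assay and not a number. That single limit is the only read-out on the set, as the limit of > 150000 nM in this assay, at which 1 of the 2 values shown sits, records. For compound 2 no figure exists in this assay, so its standing on the numbers is empty; nothing can be said of any step from compound 1 to compound 2.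

The next compound, compound 3, `COC(=O)c1sc2cc(-c3ccccc3N)cnc2c1N`, differs from compound 2 by 2-aminophenyl in place of 6-fluoropyridin-3-yl on an aromatic carbon. For the measured compounds named here, no measured step exists for such a change, and the one value in hand is a limit. For compound 3 the expected outcome in this assay is therefore weak growth inhibition, with a fair chance that only a limit is returned again; the estimate for compound 3 is 100000 nM, with a range from 20000 nM to 200000 nM.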

Compound 3, concentration for 50% growth inhibition: 3800 nM
Compound 3: middle estimate off by 26-fold (1.42 log units), on the high side; the measured number lies below the stated range.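

In this assay, for the compounds shown here, compound 3 gives 3800 nM and so supplies the first number for this series, showing that a group on this aromatic carbon, two atoms from the ring nitrogen, can yield a measurable read-out of growth inhibition. With 2-aminophenyl in place of 1-methyl-1H-pyrazol-4-yl, the series shows an at least 39-fold lower number from compound 1 to compound 3 (1.59 log units; beyond the scatter), a large step whose full size cannot be fixed, since compound 1 holds only a limit and not a number: the limit of > 150000 nM in this assay, at which 1 of the 3 values shown sits. Going by these compounds alone, the change from compound 2 to compound 3 cannot be read, as compound 2 has no result, so the only comparison rests on a swap of the whole aromatic group and does not separate the ring from its amine.

On these data alone, it remains open whether the amine or the carbon-only ring of 2-aminophenyl accounts for the step, which an unsubstituted phenyl, or a hydroxyl or methyl group in place of the amine, would help to separate. The compounds shown also leave open how far the result depends on the shared ester, for which a carboxylic acid or an amide would be the direct comparison.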